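The source may hold more compounds than are shown below. What is called first, only, known or untested is meant among the compounds shown, and "the series" means these compounds.

The compounds here share one core, a ring system carrying a phenyl group, with a saturated chain hanging from an aromatic nitrogen and a polar end-group on that chain. Among the compounds with values here, compound 1 has the structure `N#CNC(=N)NCCCCCn1nc(-c2ccccc2)ccc1=O` and in a functional assay on the whole organism with Rattus norvegicus as the target, at a dose of 100 mg/kg (a lower number here means less inhibition, a higher number more inhibition at the dose given (going by the name of the read-out)), compound 1 gives 31%, the lower of the two numbers measured so far. Within the data shown here, its only neighbour with a value is compound 2, `O=c1ccc(-c2ccccc2)nn1CCCC/N=C(\S)Nc1ccc(F)cc1`, which carries a thiourea end-group on a shorter chain and in this assay compound 2 gives 45.6%, a difference that lies beyond the usual scatter.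

The unmeasured compound 3 has the structure `C/N=C(\S)NCCCCCCn1nc(-c2ccccc2)ccc1=O`. Compared with compound 1, the change is a group of 6 heavy atoms (3 carbon, 2 nitrogen, 1 sulfur; no ring) in place of a group of 6 heavy atoms (2 carbon, 4 nitrogen; no ring), on a saturated chain carbon, five bonds along the chain from an aromatic nitrogen. The entering group is a thiourea, the same kind of end-group that compound 2 carries, though here capped by a methyl rather than an aromatic ring. Among the measured compounds shown here, no directly comparable step has been measured, so any expectation rests on the higher value of compound 2 with its thiourea end. A modest rise is expected, the step from compound 1 to compound 3 being estimated at a number 9 percentage points higher from compound 1 to compound 3 (within the scatter), close to the edge of the scatter. Compound 3 is therefore expected to give about 40% in this assay, in a range from 24% to 56%.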

Compound 3, a percentage reported as inhibition, in the whole organism at one dose (the size of the read-out at that dose, not a potency): 22.2%
Estimate against measurement, compound 3: 17.8 percentage points above; measured number below the stated range.
By their numbers in this assay, from the lowest: compounds 3 and 1 (each within the scatter of the next); then compound 2.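

Within the data shown here, the first direct comparison at this place, on a saturated chain carbon, five bonds along the chain from an aromatic nitrogen, reads a number 8.8 percentage points lower from compound 1 to compound 3 (within the scatter) in this assay. At this single dose, the sulfur-containing thiourea with its methyl cap and the all-nitrogen end-group of compound 1 therefore cannot be told apart, and a thiourea end-group does not on this evidence set a compound apart from compound 1, while compound 2 differs from compound 3 in more than one place and cannot be read against it directly. Nothing shown here offers an explanation for how these two end-groups compare.

Still open, as far as these compounds go, is what decides the value of compound 2 in this assay, whether the 4-fluorophenyl cap on its thiourea, its chain or both together, a question that only a compound changed in one of these places could settle. From the compounds shown here alone, it is equally open whether a quite different end-group on this chain, such as a simple amine or a carboxylic acid, would move the number beyond the usual scatter.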